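Swapping the aryl group on the amide carbonyl

The source may hold more compounds than are shown below. What is called first, only, known or untested is meant among the compounds shown, and "the series" means these compounds.

Compound 1 `Cc1cc(C)cc(C(=O)NCN2CCC(c3cccc[n+]3[O-])CC2)c1` gives 56% in a functional assay on HEK293 cells for agonist activity at D(4) dopamine receptor (Homo sapiens), read by FLIPR; on this read-out higher numbers stand for larger maximal responses and lower numbers for smaller maximal responses.
Compound 2 `O=C(CN1CCC(c2cccc[n+]2[O-])CC1)Nc1ccc(F)cc1` gives 71% in this assay.
Compound 3 `O=C(CN1CCC(c2cccc[n+]2[O-])CC1)Nc1cccc(Cl)c1Cl` gives 66% in this assay.

Compound 1 stands lowest of the three measured numbers: within the scatter of compound 3, yet beyond the scatter below compound 2. Compound 4 `Cc1cc(C(=O)NCN2CCC(c3cccc[n+]3[O-])CC2)ccc1Cl` differs from compound 1 as follows: 4-chloro-3-methylphenyl in place of 3,5-dimethylphenyl on a carbonyl carbon. Within the data shown here, the only measured step, a number 5 percentage points lower from compound 2 to compound 3 (within the scatter), exchanges an aryl group on the amide-type nitrogen rather than on the carbonyl carbon and stays within the scatter, so it bears on this change only loosely. Among the measured compounds shown here, no step on the carbonyl side of the amide has been measured. In this assay the expected step is therefore none beyond the scatter: a number 2 percentage points higher from compound 1 to compound 4 (within the scatter). For compound 4 the estimate is 58%, expected between 45% and 72%.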

Compound 4, largest response reached (reported as efficacy), in percent of the reference or control that the assay uses: 62%
Compound 4: middle estimate off by 4 percentage points, on the low side, within the range that was stated.
By their numbers in this assay, from the lowest: compounds 1, 4, 3 and 2 (each within the scatter of the next, the first and the last beyond it).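

Among these compounds, on a carbonyl carbon, 4-chloro-3-methylphenyl in place of 3,5-dimethylphenyl gives in this assay the first measured step on this side of the amide, a number 6 percentage points higher from compound 1 to compound 4 (within the scatter). This position therefore takes a chlorine in place of one methyl, at an equal count of heavy atoms, without a change in maximal response beyond the scatter. No measured evidence bears on this result.

Open, as far as these compounds go, is how the maximal response would move with a group of another kind on the carbonyl carbon, such as cyclohexyl or 4-methoxyphenyl. Also open, from the compounds shown here alone, is whether the unsubstituted phenyl would stay within the scatter of these two aryl groups.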